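The source may report more compounds than this note shows. Statements on the series, on what has been measured and on what is new or still open speak of the compounds shown alone.

Of the compounds shown here, three that share one core have been tested in a functional assay on CCRF-CEM cells (Homo sapiens) for inhibition, read by sulforhodamine B assay, with a stated time of 48 h; a higher number here means a weaker inhibitor of growth, a lower number a stronger inhibitor of growth. Compound 1, `COc1cc(-c2cc(/C=C/C(=O)c3ccc(N)cc3)[nH]n2)cc(OC)c1OC`, gives 4170 nM. Compound 2, `COc1ccc(-c2cc(/C=C/C(=O)c3ccc(OC)c(OC)c3)[nH]n2)cc1`, gives 4140 nM, and compound 3, `COc1ccc(-c2cc(/C=C/C(=O)c3cc(OC)c(OC)c(OC)c3)[nH]n2)cc1OC`, gives 3130 nM. Compound 1 has the highest of the three numbers, but its gap to compound 2 and its gap to compound 3 both lie within the scatter of repeated measurements, so the three cannot be told apart on these figures.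

Compound 4, `COc1cc(-c2cc(/C=C/C(=O)c3ccc(F)c(F)c3)[nH]n2)cc(OC)c1OC`, has not yet been measured. It differs from compound 1 in one place: 3,4-difluorophenyl in place of 4-aminophenyl on a carbonyl carbon. Within the data shown here, no step between measured compounds covers this change, so nothing in the figures so far shows its direction or size. The three measured compounds, which differ from one another in their methoxy and amino groups, sit close together, which suggests that swaps of this kind have moved the numbers little here. The expected step from compound 1 to compound 4 is therefore small, a 1.2-fold lower number from compound 1 to compound 4 (0.08 log units; within the scatter), with no confident direction. Compound 4 is estimated to give about 3500 nM in this assay, and is expected to fall between 1200 nM and 10000 nM.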

Compound 4, concentration for total growth inhibition: 47200 nM
Compound 4: the middle estimate sits 13-fold (1.13 log units) below what was measured; the measured number lies above the stated range.
By their numbers in this assay, from the lowest: compounds 3, 2 and 1 (each within the scatter of the next); then compound 4.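

In this assay, putting 3,4-difluorophenyl in place of 4-aminophenyl on a carbonyl carbon gives an 11-fold higher number from compound 1 to compound 4 (1.05 log units; beyond the scatter), so compound 4 is clearly a weaker inhibitor of growth than compound 1. Among these compounds, this is the first direct evidence that the group at this place can matter a great deal: no two earlier compounds differed in one place only, so their similar numbers could not show it. The change takes away a group counted with a hydrogen-bond donor and acceptor and brings in one counted with neither, but no measurement here ties that difference, or any other feature of the swap, to the loss of growth inhibition.

The swap removes the amine and adds two fluorines in a single step, so the compounds shown cannot tell whether losing the amine, gaining the fluorines, or both together account for the change. A plain phenyl ring, a phenyl ring carrying a hydroxyl group or a dimethylamino group, or one with a single fluorine at this place would help separate these possibilities.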